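Carbonate and pivalate ester series: stability readings at the limit

This account rests on a few compounds, and the source may have more. Where it says the series, first, only, none or still open, it means among the compounds named here.

Compound 1 `CC(C)OC(=O)OCOC(=O)C1=C(S[C@@H]2CN[C@H](C(=O)Nc3cccc(C(=O)O)c3)C2)[C@H](C)[C@@H]2[C@@H]([C@@H](C)O)C(=O)N12` — in an ADME assay for metabolic stability, read by LC-MS, with a stated time of 3 h, at pH 6.5, tested at 50 uM (a lower number here means that less of the compound is left, a higher number that more of the compound is left), compound 1 gives > 95%, a limit of the assay.
Compound 2 `CCOC(=O)OCOC(=O)C1=C(S[C@@H]2CN[C@H](C(=O)Nc3cccc(C(=O)O)c3)C2)[C@H](C)[C@@H]2[C@@H]([C@@H](C)O)C(=O)N12` — in this assay compound 2 gives > 95%, a limit.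
Compound 3 `C[C@@H](O)[C@H]1C(=O)N2C(C(=O)O)=C(S[C@@H]3CN[C@H](C(=O)Nc4cccc(C(=O)OCOC(=O)C(C)(C)C)c4)C3)[C@H](C)[C@H]12` — in this assay compound 3 gives > 95%, a limit.

The change from compound 1 to compound 2 is hydrogen in place of methyl on a saturated chain carbon bound to an oxygen next to a carbonyl group and a saturated chain carbon and reads as a step that the two limits leave unreadable from compound 1 to compound 2, because all three values sit at the limit of > 95% in this assay, at which 3 of the 3 values shown sit. How the cores of compound 1 and compound 3 differ is not broken down here.

Compound 4 `CC(C)C(=O)OCOC(=O)c1cccc(NC(=O)[C@@H]2C[C@H](SC3=C(C(=O)O)N4C(=O)[C@H]([C@@H](C)O)[C@H]4[C@H]3C)CN2)c1` carries hydrogen in place of methyl on a saturated chain carbon bound to a carbonyl carbon and two saturated chain carbons. This is the same kind of change as in compound 2, not the same: there the place was a saturated chain carbon bound to an oxygen next to a carbonyl group and a saturated chain carbon, here it is a saturated chain carbon bound to a carbonyl carbon and two saturated chain carbons.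

Compound 4 is expected to stay at the limit, a step that the limit leaves unreadable from compound 3 to compound 4, resting on compound 3 at > 95% and on (the limit of > 95% in this assay, at which 3 of the 3 values shown sit). The estimate for compound 4 is 96%.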

Compound 4, percent of the compound remaining: > 95%
Compound 4 gave a limit, no number; the forecaster's own chance of this, stated with the estimate: 80%; the middle value is on the limit's open side.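

Compound 3 and compound 4 yield no readable step, because the readings stop at a limit: the limit of > 95% in this assay, at which 4 of the 4 values shown sit.

As far as these compounds go, whether the change from tert-butyl to isopropyl shifts stability in this assay, and how the four compounds rank, stays open.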